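Selenocyanate side chain on the shared core: compound 3 to compound 4

The source may hold more compounds than are shown below. What is called first, only, known or untested is meant among the compounds shown, and "the series" means these compounds.

Going by the values given here, compound 3 `COc1ccc(N(C)c2nc(C)nc3ccccc23)cc1C(=O)OCCCC[Se]C#N` stands lowest of the three numbers so far in a functional assay on MDA-MB-231 cells (Homo sapiens) for inhibition, read by MTT assay, with a stated time of 48 h; a higher number here means a weaker inhibitor, a lower number a stronger inhibitor: compound 3 gives 554 nM. Compound 1 `COc1ccc(N(C)c2nc(C)nc3ccccc23)cc1C(=O)OCCC[Se]C#N` gives 1180 nM, and compound 2 `COc1ccc(N(C)c2nc(C)nc3ccccc23)cc1OCCCCC[Se]C#N` gives 4410 nM; the nearest neighbour of compound 3 is compound 1, with a 2.1-fold lower number from compound 1 to compound 3 (0.33 log units; beyond the scatter), and the furthest is compound 2, with an 8.0-fold lower number from compound 2 to compound 3 (0.90 log units; beyond the scatter).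

Compound 4 `COc1ccc(N(C)c2nc(C)nc3ccccc23)cc1C[Se]C#N` differs from compound 3 in one place: a group of 4 heavy atoms (2 carbon, 1 nitrogen, 1 selenium; no ring) in place of a group of 10 heavy atoms (6 carbon, 1 nitrogen, 2 oxygen, 1 selenium; no ring), on an aromatic carbon.

Among the compounds with values here, two measured steps bear on this. The step of a 2.1-fold lower number from compound 1 to compound 3 (0.33 log units; beyond the scatter) shows that one more saturated chain carbon three bonds along from the oxygen next to the carbonyl group lowered the number; compound 4 goes the opposite way, with a much shorter group and no carbonyl at all. The step of an 8.0-fold lower number from compound 2 to compound 3 (0.90 log units; beyond the scatter) shows that swapping the group on the aromatic carbon moved the number substantially. A step toward a higher number in this assay is therefore expected, beyond the scatter but modest.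

Compound 4 is estimated at 2000 nM, with a range of 600 nM to 7000 nM, which is expected to mean a 3.6-fold higher number from compound 3 to compound 4 (0.56 log units; beyond the scatter).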

Compound 4, half-maximal inhibitory concentration: 153 nM
Compound 4: the middle estimate sits 13-fold (1.12 log units) above what was measured, outside the stated range (below it).
By their numbers in this assay, from the lowest: compound 4; then compound 3; then compound 1; then compound 2.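

At this aromatic carbon, ortho to a methoxy group, the group of 4 heavy atoms gives the lowest number of the series in this assay, with a 3.6-fold lower number from compound 3 to compound 4 (0.56 log units; beyond the scatter) and a 7.7-fold lower number from compound 1 to compound 4 (0.89 log units; beyond the scatter) and a 29-fold lower number from compound 2 to compound 4 (1.46 log units; beyond the scatter) as its steps. Group size alone does not order the four compounds: the smallest group, in compound 4, stands lowest, yet the largest group, in compound 3, stands lower than the groups of 9 heavy atoms in compound 1 and compound 2. No accompanying measurement accounts for these steps.

As far as these compounds go, it remains open whether a thiocyanate in place of the selenocyanate would keep the number of compound 4. Also open, from the compounds shown here alone, is how an ethyl chain carrying the selenocyanate on this aromatic carbon would compare with compound 4.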